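Two Aryl Swaps on One Core, Same Dose Required

The source may report more compounds than this note shows. Statements on the series, on what has been measured and on what is new or still open speak of the compounds shown alone.

Measured compounds: compound 1 `SC1=NC(n2nc(-c3ccccc3)nc2-c2ccccc2)=CC(c2ccccc2Cl)N1` gives 300 mg/kg in a functional assay on the whole organism with Mus musculus as the target, in the maximal electroshock model, with a stated time of 4 h; a higher number here means that more compound is needed for the effect, a lower number that less compound is needed; compound 2 `Oc1ccc(C2C=C(n3nc(-c4ccccc4)nc3-c3ccccc3)N=C(S)N2)cc1` gives 300 mg/kg.

Compound 2 stands level with compound 1 in this assay, the step of no change at the digits printed from compound 1 to compound 2 (within the scatter) lying within the scatter. Compound 3 `COc1ccc(C2C=C(n3nc(-c4ccccc4)nc3-c3ccccc3)N=C(S)N2)c(OC)c1` differs from compound 2 by 2,4-dimethoxyphenyl in place of 4-hydroxyphenyl on a saturated ring carbon. Within the data shown here, the only step known to bear on this place is no change at the digits printed from compound 1 to compound 2 (within the scatter), where one aryl group replaced another without visible effect, so no change beyond the scatter is expected here either. Compound 3 is therefore expected to give 300 mg/kg, within 100 mg/kg to 600 mg/kg, a step of no change at the digits printed from compound 2 to compound 3 (within the scatter).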

Compound 3, minimum effective dose: 300 mg/kg
Compound 3: middle estimate and measured number agree at the digits printed; the range from low to high includes it.
By their numbers in this assay, from the lowest: compounds 1, 2 and 3 (each within the scatter of the next).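

Putting 2,4-dimethoxyphenyl in place of 4-hydroxyphenyl on the saturated ring carbon gives no change at the digits printed from compound 2 to compound 3 (within the scatter) in this assay, and putting it in place of 2-chlorophenyl gives no change at the digits printed from compound 1 to compound 3 (within the scatter) in the same test. The entering group has 10 heavy atoms against 7 for 4-hydroxyphenyl and 0 hydrogen-bond donors against 1, yet the required dose stays level. Nothing available explains this sameness.

All three groups here are substituted phenyl rings. As far as these compounds go, whether an amine, a carboxylic acid or a longer alkyl chain at this carbon would shift the dose remains open.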